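The source may hold more compounds than are shown below. What is called first, only, known or untested is meant among the compounds shown, and "the series" means these compounds.

Compound 1 `CS(=O)(=O)c1ccc(Nc2ncc(F)c(Nc3nc4ccccc4s3)n2)cc1` stands second highest of the three numbers in a functional assay on HCT-116 cells (Homo sapiens) for antiproliferative activity, read by MTT assay, with a stated time of 48 h (on this read-out lower numbers stand for stronger inhibition and higher numbers for weaker inhibition), where compound 1 gives 3270 nM. Compound 2 `NS(=O)(=O)c1ccc(Nc2ncc(F)c(Nc3nc4ccccc4s3)n2)cc1` gives 3260 nM, and compound 3 `CS(=O)(=O)c1ccc(Nc2nccc(Nc3nc4ccccc4s3)n2)cc1` gives 8370 nM. The change from compound 1 to compound 4 `COc1ccc2nc(Nc3nc(Nc4ccc(S(C)(=O)=O)cc4)ncc3F)sc2c1` is methoxy in place of hydrogen on an aromatic carbon. Neither measured step touches the ring where the methoxy enters: a 1.0-fold lower number from compound 1 to compound 2 (0.00 log units; within the scatter), and a 2.6-fold higher number from compound 1 to compound 3 (0.41 log units; beyond the scatter). For the measured compounds named here, no measured pair speaks to a methoxy group on the shared core, so nothing in these data argues for a step beyond the scatter in this assay in either direction. Compound 4 is therefore expected at 3000 nM, with a range from 1000 nM to 9000 nM. That estimate means an expected step of a 1.1-fold lower number from compound 1 to compound 4 (0.04 log units; within the scatter), within the usual scatter.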

Compound 4, half-maximal inhibitory concentration: 2630 nM
Compound 4: the middle estimate sits 1.1-fold (0.06 log units) above what was measured; the range from low to high includes it.
By their numbers in this assay, from the lowest: compounds 4, 2 and 1 (each within the scatter of the next); then compound 3.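

In this assay, for the compounds shown here, the step for methoxy in place of hydrogen is a 1.2-fold lower number from compound 1 to compound 4 (0.09 log units; within the scatter) and so gives the first reading on the six-membered aromatic ring of carbon only, which the earlier steps left untouched. At this carbon, meta to a fused ring and para to a fused ring, the methoxy group leaves the number within the scatter. Nothing measured here accounts for this result.

Only this one group at this one carbon is shown. On these data alone, whether an amine, a carboxylic acid or a longer chain such as ethoxy would give a step beyond the scatter stays open.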